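Sulfur placement within the chain of compound 3

This account rests on a few compounds, and the source may have more. Where it says the series, first, only, none or still open, it means among the compounds named here.

Compound 1, `O=C(CCCCCCc1ccccn1)c1ncc(-c2ccccn2)o1`: 120 nM
Compound 2, `Nc1ccc(CCCCCCC(=O)c2ncc(-c3ccccn3)o2)cc1`: 3 nM
Compound 3, `O=C(CCCCSCc1ccccc1)c1ncc(-c2ccccn2)o1`: 25 nM

In an assay for inhibition of Fatty-acid amide hydrolase 1 (Rattus norvegicus) (a lower number here means a stronger inhibitor, a higher number a weaker inhibitor), compound 3 holds the second highest number of the three, with compound 1 above it and compound 2 below it. For the measured compounds named here, the only measured step at the same place in the chain is a 4.8-fold lower number from compound 1 to compound 3 (0.68 log units; beyond the scatter), and that step exchanged the whole group. The other step, a 40-fold lower number from compound 1 to compound 2 (1.60 log units; beyond the scatter), concerns a different place and a different group. Compound 4, `O=C(CCCCCSc1ccccc1)c1ncc(-c2ccccn2)o1`, differs from compound 3 by (phenylsulfanyl)methyl in place of benzylsulfanyl on a saturated chain carbon, four bonds along the chain from a carbonyl carbon. Going by the values given here, no measured pair separates two arrangements of the same atoms, so neither step gives a direction. The expected step is no change at the digits printed from compound 3 to compound 4 (within the scatter), not beyond the scatter. Compound 4 is therefore estimated at 25 nM, within a range of 8 nM to 80 nM.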

Compound 4, inhibition constant: 3 nM
Estimate against measurement, compound 4: 8.3-fold (0.92 log units) above; the whole stated range lies above it.
By their numbers in this assay, from the lowest: compounds 2 and 4 (each within the scatter of the next); then compound 3; then compound 1.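

In this assay, the same atoms joined differently give an 8.3-fold lower number from compound 3 to compound 4 (0.92 log units; beyond the scatter), so where the sulfur sits in the chain matters even with no change in the counted make-up of the group. The unsubstituted phenylsulfanyl chain shows no change at the digits printed from compound 2 to compound 4 (within the scatter), and it also gives a 40-fold lower number from compound 1 to compound 4 (1.60 log units; beyond the scatter), so the 4-aminobenzyl group of compound 2 is not required for a number at this level. No evidence here bears on the reason for the shift from compound 3 to compound 4. Still open, from the compounds shown here alone, is whether an ether oxygen or a sulfone in place of the sulfur, or a longer chain, holds this number. Also open, going by these compounds, is whether an amine on the phenyl ring of compound 4 changes it.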